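The compounds below may be only part of what the source reports. "The series", "measured", "known", "first", "only" and "open" are said of these compounds alone.

For the measured compounds named here, compound 1 `COc1ccc(-c2cn(C/C=C3\OC(=O)C(OCc4ccccc4)=C3OCc3ccccc3)nn2)cc1` is one of two compounds so far tested in an ADME assay on HFF cells (Homo sapiens) for cytotoxicity, read by MTT assay, with a stated time of 72 h; on this read-out lower numbers stand for stronger inhibition and higher numbers for weaker inhibition. In this assay compound 1 gives > 100000 nM, which is a limit of the assay rather than a measured number. Compound 2 `COc1ccccc1-c1cn(C[C@H](O)[C@H]2OC(=O)C(OCc3ccccc3)=C2OCc2ccccc2)nn1`, built on a different core and carrying a different aromatic substituent, in this assay gives 50 nM. Going by the values given here, no single structural change connects compound 1 with compound 2, so the two values show only that compound 2 sits well inside the range the assay can report, whereas compound 1 sits at the limit (the limit of > 100000 nM in this assay, at which 1 of the 2 values shown sits).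

Compound 3 `CCCCCc1ccc(-c2cn(C/C=C3\OC(=O)C(OCc4ccccc4)=C3OCc3ccccc3)nn2)cc1` has not yet been measured. It differs from compound 1 in one place (pentyl in place of methoxy on an aromatic carbon). Among the compounds with values here, no measured pair in this set shows what such a swap does, so the expectation for compound 3 rests on compound 1 alone, whose only anchor is the limit (the limit of > 100000 nM in this assay, at which 1 of the 2 values shown sits). Compound 3 is therefore expected to stay close to that limit, with the step of a number no higher from compound 1 to compound 3 (the limit leaves the size open) expected to be no larger than the usual scatter. Compound 3 is estimated at 100000 nM, within a range from 20000 nM to 300000 nM.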

Compound 3, half-maximal inhibitory concentration: > 100000 nM
Compound 3: only a limit was reported; the forecaster's own chance of this, stated with the estimate: 55%; the middle value sits exactly at the limit.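

In this assay, for the compounds shown here, compound 1 and compound 3 both give only a limit of the assay rather than a number, so no step between them can be read: the limit of > 100000 nM in this assay, at which 2 of the 3 values shown sit.

The compounds shown leave open how far each lies beyond that limit, and whether pentyl in place of methoxy changes cytotoxicity at all.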